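This account rests on a few compounds, and the source may have more. Where it says the series, first, only, none or still open, it means among the compounds named here.

Compound 1 `O=C(Nc1cccc(-c2oc3cc(-c4ccc(F)cc4)ccc3c(=O)c2O)c1)c1ccc(F)cc1`: in a functional assay on A549 cells (Homo sapiens) for antiproliferative activity, read by CCK-8 assay, with a stated time of 72 h (a lower number here means a stronger inhibitor, a higher number a weaker inhibitor), compound 1 gives 6930 nM.
Compound 2 `O=C(Nc1cccc(-c2oc3cc(-c4ccc(F)cc4)ccc3c(=O)c2O)c1)c1ccc(Br)cc1F`: in this assay compound 2 gives 46100 nM.

Within the data shown here, compound 2 holds the higher of the two numbers in this assay; the only measured step, a 6.7-fold higher number from compound 1 to compound 2 (0.82 log units; beyond the scatter), separates it from compound 1. Compound 3 `Cc1cc(C)cc(C(=O)Nc2cccc(-c3oc4cc(-c5ccc(F)cc5)ccc4c(=O)c3O)c2)c1` follows from compound 2 by 3,5-dimethylphenyl in place of 4-bromo-2-fluorophenyl on a carbonyl carbon. Among the measured compounds shown here, the one measured step concerns the same carbonyl carbon, yet it exchanged one halogen-bearing ring for another, whereas here the halogens leave and methyl groups enter; it therefore shows only the scale a change at this position can reach, not its direction for this particular swap. The expected step for compound 3 is a 3.1-fold lower number from compound 2 to compound 3 (0.49 log units; beyond the scatter), a move back toward the number of compound 1, carried with wide uncertainty. The estimate for compound 3 in this assay is 15000 nM, with a range from 4000 nM to 60000 nM.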

Compound 3, half-maximal inhibitory concentration: 3740 nM
Beside the measured number, compound 3's estimate is 4.0-fold (0.60 log units) above it; the measured number lies below the stated range.
By their numbers in this assay, from the lowest: compounds 3 and 1 (each within the scatter of the next); then compound 2.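

In this assay, among these compounds, replacing 4-bromo-2-fluorophenyl with 3,5-dimethylphenyl on the carbonyl carbon reverses the earlier rise in the number, with a 12-fold lower number from compound 2 to compound 3 (1.09 log units; beyond the scatter) as the largest step so far. The further step of a 1.9-fold lower number from compound 1 to compound 3 (0.27 log units; within the scatter) places the 3,5-dimethylphenyl and 4-fluorophenyl rings level, so among these three compounds a halogen on this ring is not required for the lower numbers, and only the 4-bromo-2-fluorophenyl ring stands apart. Nothing available bears on why these rings differ.

Going by these compounds, it remains open whether the bromine, the fluorine or their combination in compound 2 goes with its higher number, and whether one methyl would do the work of two. On these data alone, the effect of an amine or a carboxylic acid on this ring is also open.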